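A few compounds are considered here, and "the series" means these few. Any claim that something is new, unique, unknown or untested is made for them only; others in the source may bear on it.

Compound 1 `COc1ccc(-c2cc(/C=C/C(=O)c3ccc(N)cc3)[nH]n2)cc1` gives 2060 nM in a functional assay on OVCAR-5 cells (Homo sapiens) for inhibition, read by sulforhodamine B assay, with a stated time of 48 h (a lower number here means a stronger inhibitor of growth, a higher number a weaker inhibitor of growth), the lowest of the three numbers recorded so far. Going by the values given here, compound 2 `COc1cc(-c2cc(/C=C/C(=O)c3ccc(Cl)c(Cl)c3)[nH]n2)cc(OC)c1OC` gives 20500 nM and compound 3 `COc1cc(-c2cc(/C=C/C(=O)c3ccc(F)c(F)c3)[nH]n2)cc(OC)c1OC` gives 4480 nM; the only single-point step among the measured compounds is a 4.6-fold lower number from compound 2 to compound 3 (0.66 log units; beyond the scatter), and it concerns the ring on the carbonyl carbon, not the ring that changes here. Compound 4 `COc1ccc(-c2cc(/C=C/C(=O)c3ccc(N)cc3)[nH]n2)cc1OC` differs from compound 1 by methoxy in place of hydrogen on an aromatic carbon. Compounds 2 and 3 carry three methoxy groups on the ring attached to the core, but they also carry a different group on the carbonyl carbon, so their values show only what two changes together produce and say nothing on their own about adding a methoxy group. Among the compounds with values here, no measured step bears directly on the change from compound 1 to compound 4, so a step of no size beyond the scatter is expected, a 1.2-fold higher number from compound 1 to compound 4 (0.08 log units; within the scatter). Compound 4 is estimated at 2500 nM, with an expected range from 900 nM to 7000 nM.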

Compound 4, concentration for 50% growth inhibition: 2620 nM
Beside the measured number, compound 4's estimate is 1.0-fold (0.02 log units) below it, within the range that was stated.
By their numbers in this assay, from the lowest: compounds 1, 4 and 3 (each within the scatter of the next, the first and the last beyond it); then compound 2.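

In this assay the change now has a direct reading: methoxy in place of hydrogen, on the aromatic carbon ortho to a methoxy group and meta to a large group, gives a 1.3-fold higher number from compound 1 to compound 4 (0.10 log units; within the scatter). With the group on the carbonyl carbon held constant, this position accepts the added methoxy without a step beyond the scatter, which the two-change comparisons with compound 2 and compound 3 could not show. No measured evidence bears on this result, so the step stands as a bare observation.

Still open, on these data alone, is whether a third methoxy group on this ring would stay within the scatter with the group on the carbonyl carbon of compound 1 kept in place. Also open, as far as these compounds go, is how a hydroxyl, an ethoxy or a fluorine would read at this same position.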